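Carbamoyl to cyano at two chain positions

A few compounds are considered here, and "the series" means these few. Any claim that something is new, unique, unknown or untested is made for them only; others in the source may bear on it.

Compound 1 `CCCn1c(=O)n(CCC(N)=O)c(=O)c2[nH]cnc21` and compound 2 `CCCn1c(=O)n(CCC#N)c(=O)c2[nH]cnc21` share a core and differ only in the side chain. In an assay on Cerebral cortex for binding affinity to adenosine receptor A1 (Cavia porcellus), read by radioligand binding (a lower number here means a stronger inhibitor, a higher number a weaker inhibitor), compound 1 gives 31500 nM, and compound 2 gives 15900 nM. The change is cyano in place of carbamoyl on a saturated chain carbon, two bonds along the chain from an aromatic nitrogen, and it produced a 2.0-fold lower number from compound 1 to compound 2 (0.30 log units; within the scatter).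

Compound 3 `CCCn1c(=O)n(C)c(=O)c2c1ncn2CC(N)=O` carries the same atoms joined differently; the difference between the two cores is not broken down here. For compound 3 this assay reports only a limit, > 200000 nM, which is the limit of > 200000 nM in this assay, at which 1 of the 3 values shown sits.

Compound 4 `CCCn1c(=O)n(C)c(=O)c2c1ncn2CC#N` is the not yet measured partner of compound 3. The change is cyano in place of carbamoyl on a saturated chain carbon bound to an aromatic nitrogen. Within the data shown here, it is the same kind of change as the one from compound 1 to compound 2, but the place differs: here the chain carbon is bound to an aromatic nitrogen, there it sat two bonds along the chain from an aromatic nitrogen.

The step of a number no higher from compound 3 to compound 4 (the limit leaves the size open) is expected to be small, resting on the step of a 2.0-fold lower number from compound 1 to compound 2 (0.30 log units; within the scatter) seen for compound 1 and compound 2. Compound 4 is therefore expected to sit near 200000 nM, between 80000 nM and 600000 nM, most likely again reported as a limit in this assay.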

Compound 4, inhibition constant: 6600 nM
Compound 4: the middle estimate sits 30-fold (1.48 log units) above what was measured, and the stated range ends above it.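

In this assay the change from carbamoyl to cyano does not carry over in size from one core to the other: the same change on two cores in this assay, a 2.0-fold lower number (0.30 log units; within the scatter) from compound 1 to compound 2 and an at least 30-fold lower number (1.48 log units; beyond the scatter) from compound 3 to compound 4, at least 15-fold (1.18 log units) apart, beyond the scatter of two such steps

Compound 3 is held only by a limit: the limit of > 200000 nM in this assay, at which 1 of the 4 values shown sits.

The step, an at least 30-fold lower number from compound 3 to compound 4 (1.48 log units; beyond the scatter), therefore fixes only a minimum size, and the two pairs differ in both the core and the place of the change, so they do not show which of these sets the gap.

Open, going by these compounds, is whether carbamoylmethyl to cyanomethyl on the core of compound 1 would give a step like the one on the core of compound 3, and whether a longer chain on the core of compound 3 would keep it. Also open, on these data alone, is how a carboxylic acid or an amine in place of the cyano group would read on the chain of compound 4.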